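The source may report more compounds than this note shows. Statements on the series, on what has been measured and on what is new or still open speak of the compounds shown alone.

In a functional assay on HCT-116 cells (Homo sapiens) for cytotoxicity, read by sulforhodamine B assay, with a stated time of 48 h (on this read-out higher numbers stand for weaker inhibition and lower numbers for stronger inhibition), three compounds sharing one core have been measured. Compound 1 `Cc1cc2ncc(S(=O)(=O)c3ccccc3)c(-c3ccccc3)n2n1` gives > 25 ug/mL, and this is a limit of the assay, not a number. Compound 2 `O=S(=O)(c1ccccc1)c1cnc2cc(-c3ccccc3)nn2c1-c1ccccc1` gives 1.27 ug/mL, and compound 3 `O=S(=O)(c1ccccc1)c1cnc2cc(-c3ccc(Cl)cc3)nn2c1-c1ccccc1` gives 1.64 ug/mL. Putting chloro in place of hydrogen on an aromatic carbon produced a 1.3-fold higher number from compound 2 to compound 3 (0.11 log units; within the scatter), so compound 3 stands level with compound 2. Both lie far from the limit: phenyl in place of methyl gave an at least 19-fold lower number from compound 1 to compound 2 (1.29 log units; beyond the scatter), and 4-chlorophenyl in place of methyl gave an at least 15-fold lower number from compound 1 to compound 3 (1.18 log units; beyond the scatter).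

Compound 4 `Cc1ccc(-c2c(S(=O)(=O)c3ccccc3)cnc3cc(-c4ccc(Cl)cc4)nn23)cc1` is compound 3 with methyl in place of hydrogen on an aromatic carbon, para to a large group: methyl in place of hydrogen on an aromatic carbon. The large steps replaced a whole group on the core, so they offer little guidance here. Within the data shown here, the closest precedent is the chloro step, a 1.3-fold higher number from compound 2 to compound 3 (0.11 log units; within the scatter), although it sits elsewhere in the molecule. No change beyond the scatter is therefore expected. The estimated step is a 1.1-fold lower number from compound 3 to compound 4 (0.04 log units; within the scatter). For compound 4, the expected value is 1.5 ug/mL, within an estimated range of 0.7 ug/mL to 3.5 ug/mL.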

Compound 4, half-maximal inhibitory concentration: 9.3 ug/mL
Estimate against measurement, compound 4: 6.2-fold (0.79 log units) below, and the stated range ends below it.
By their numbers in this assay, from the lowest: compounds 2 and 3 (each within the scatter of the next); then compound 4. At a limit, above all of these: compound 1.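

In this assay, going from phenyl to 4-methylphenyl adds a single carbon and gives a 5.7-fold higher number from compound 3 to compound 4 (0.75 log units; beyond the scatter), so this position on the shared core does not tolerate every small change. The chloro step, which sits elsewhere in the molecule, gave a 1.3-fold higher number from compound 2 to compound 3 (0.11 log units; within the scatter), so a small addition there had shown no such response and the earlier compounds gave no warning about this one. Only compound 1 stands at the limit of the assay, so the loss seen with compound 4 stops short of that limit: the limit of > 25 ug/mL in this assay, at which 1 of the 4 values shown sits.

The compounds shown leave open whether this loss belongs to methyl alone or would also follow from a fluoro group, a methoxy group or an amine at the same position. They also leave open whether the same methyl would have a similar effect on compound 2, which has no chloro.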